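This account rests on a few compounds, and the source may have more. Where it says the series, first, only, none or still open, it means among the compounds named here.

In an ADME assay on McCoy cells (Mus musculus) for antiproliferative activity, read by sulforhodamine B assay, with a stated time of 48 h (a lower number here means a stronger inhibitor, a higher number a weaker inhibitor), compound 2 `CC(C)(C)OC(=O)NCCCC[C@H]1N=C2C[C@H]3C[C@H](C3(C)C)[C@@]2(C)OC1=O` gives no number but only a limit of the assay, > 1300000 nM. Its close relative compound 1 `CC(C)(C)OC(=O)NCCC[C@@H]1N=C2C[C@@H]3C[C@@H](C3(C)C)[C@]2(C)OC1=O` likewise reaches only a limit in this assay, > 1200000 nM. Among the compounds with values here, every value known here is therefore a limit: the limit of > 1200000 nM in this assay, at which 1 of the 2 values shown sits, and the limit of > 1300000 nM in this assay, at which 1 of the 2 values shown sits, leave no measured potency to compare and no measured step to build on.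

Compound 3 `CC(C)(C)OC(=O)NCCCC[C@@H]1N=C2C[C@@H]3C[C@@H](C3(C)C)[C@]2(C)OC1=O` differs from compound 2 in the two compounds have the same atoms and bonds and differ only in configuration as drawn: 4 of 4 stereo elements differ (all stereocentres are inverted: mirror images); a stereocentre at a saturated ring carbon is drawn R in compound 2 and S in compound 3; a stereocentre at a saturated ring carbon is drawn R in compound 2 and S in compound 3; a stereocentre at a saturated ring carbon is drawn R in compound 2 and S in compound 3; a stereocentre at a saturated ring carbon is drawn R in compound 2 and S in compound 3. With both known compounds sitting at the limit of this assay, the change from compound 2 to compound 3 is not expected to bring a shift beyond the scatter; the estimated step that the limit leaves unreadable from compound 2 to compound 3 is essentially none, and compound 3 is expected to stay at or past the limit as well. Compound 3 is thus estimated at 1500000 nM in this assay, within a range from 300000 nM to 6000000 nM, most likely reported as a limit once more.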

Compound 3, half-maximal inhibitory concentration: > 800000 nM
Compound 3: no number, only a limit; the forecaster's own chance of this, stated with the estimate: 85%; the middle value does not contradict the limit.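

In this assay, within the data shown here, compound 3 gives only the limit > 800000 nM and no number, so no step from compound 1 or compound 2 to compound 3 can be read. The compounds shown leave open whether chain length or configuration as drawn changes antiproliferative activity at all.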